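Benzyloxy in place of methoxy on a flavone core

This account rests on a few compounds, and the source may have more. Where it says the series, first, only, none or still open, it means among the compounds named here.

Measured compounds:
compound 1, `COc1cc2oc(-c3ccccc3)cc(=O)c2c(O)c1OCCCCN1CCN(C)CC1`, 32000 nM
compound 2, `COc1cc2oc(-c3ccccc3)cc(=O)c2c(O)c1OCCCN1CCCC1`, 6000 nM
compound 3, `COc1cc2oc(-c3ccccc3)cc(=O)c2c(O)c1OCCCN1CCN(C)CC1`, 18000 nM

In a functional assay on A549 cells (Homo sapiens) for antiproliferative activity, read by MTT assay, with a stated time of 48 h (a lower number here means a stronger inhibitor, a higher number a weaker inhibitor), compound 1 gives 32000 nM, the highest of the three numbers; compound 3 sits nearest, at a 1.8-fold lower number from compound 1 to compound 3 (0.25 log units; within the scatter), and compound 2 furthest, at a 5.3-fold lower number from compound 1 to compound 2 (0.73 log units; beyond the scatter). Compound 4, `CN1CCN(CCCCOc2c(OCc3ccccc3)cc3oc(-c4ccccc4)cc(=O)c3c2O)CC1`, differs from compound 1 by phenyl in place of hydrogen on a saturated chain carbon bound to an oxygen on an aromatic ring, in other words methoxy to benzyloxy. Going by the values given here, none of the measured steps touches this place: a 5.3-fold lower number from compound 1 to compound 2 (0.73 log units; beyond the scatter), a 1.8-fold lower number from compound 1 to compound 3 (0.25 log units; within the scatter) and a 3.0-fold higher number from compound 2 to compound 3 (0.48 log units; beyond the scatter) all vary the amine at the end of the chain, so they give no guide to the size or direction of the step in this assay. The expectation for compound 4 therefore stays near compound 1, at 20000 nM within 4000 nM to 100000 nM, an expected step of a 1.6-fold lower number from compound 1 to compound 4 (0.20 log units; within the scatter).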

Compound 4, half-maximal inhibitory concentration: 4400 nM
Estimate against measurement, compound 4: 4.5-fold (0.66 log units) above; measured number inside the range.
By their numbers in this assay, from the lowest: compounds 4 and 2 (each within the scatter of the next); then compounds 3 and 1 (each within the scatter of the next).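

In this assay, methoxy to benzyloxy gives a 7.3-fold lower number from compound 1 to compound 4 (0.86 log units; beyond the scatter) on the core of compound 1, which shows that this place, and not only the amine at the end of the chain, can move the number. Here the added phenyl lowers the number. No measurement shown accounts for this step. Going by these compounds, whether benzyloxy lowers the number by a similar step alongside the pyrrolidin-1-yl group of compound 2 remains open. So does how a fluorobenzyl group or a phenethyl group on the same oxygen would compare.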